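Swapping Sulfamoyl for Carbamoyl in Compound 1

A few compounds are considered here, and "the series" means these few. Any claim that something is new, unique, unknown or untested is made for them only; others in the source may bear on it.

Of the compounds shown here, three have been measured in a functional assay on L1210 cells (Mus musculus) for antiproliferative activity; on this read-out lower numbers stand for lower potency and higher numbers for higher potency (the scale is a negative logarithm). Compound 1 `CN(C)/N=N/c1ccc(S(N)(=O)=O)cc1C(N)=O` gives 3.32, the lowest of the three numbers. Compound 3 `CCCN(C)/N=N/c1nc[nH]c1C(N)=O` gives 3.58, a value within the scatter of that of compound 1, while compound 2 `CCCCN(C)/N=N/c1c(C(N)=O)n[nH]c1C` gives 3.83, which stands beyond the scatter above compound 1. Compound 4 `CN(C)/N=N/c1ccc(C(N)=O)cc1C(N)=O` has not yet been measured; it differs from compound 1 in one place: carbamoyl in place of sulfamoyl on an aromatic carbon. Within the data shown here, no step between two measured compounds bears on this change, so the expectation rests on compound 1 alone. The step of a number 0.18 log units higher from compound 1 to compound 4 (within the scatter) is expected to be small, in either direction, and not beyond the scatter. Compound 4 is therefore estimated at 3.5, with a range from 3 to 4.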

Compound 4, logarithm of the reciprocal of the active concentration, log(1/C): 3.27
Compound 4: the middle estimate sits 0.23 log units above what was measured; the range from low to high includes it.
By their numbers in this assay, from the lowest: compounds 4, 1, 3 and 2 (each within the scatter of the next, the first and the last beyond it).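

Carbamoyl in place of sulfamoyl on this aromatic carbon gives the first direct reading at this position in this assay: a number 0.05 log units lower from compound 1 to compound 4 (within the scatter). Among these compounds, on the core of compound 1, this exchange therefore stays inside the scatter, something the earlier compounds, which differ in more than one place, could not show. Nothing available explains why the two groups read alike.

From the compounds shown here alone, whether a carboxylic acid or an amine on this aromatic carbon would also stay within the scatter of compound 1 remains open.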